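A few compounds are considered here, and "the series" means these few. Any claim that something is new, unique, unknown or untested is made for them only; others in the source may bear on it.

Measured compounds:
- compound 1 `O=C(Nc1ccc(S(=O)(=O)Nc2ccccc2)cc1)c1cc(F)c(Cl)cc1F`: 37%
- compound 2 `O=C(Nc1cccc(S(=O)(=O)Nc2ccccc2)c1)c1ccc(Cl)cc1Cl`: "not determined" (no result reported)
- compound 3 `O=C(Nc1ccc(S(=O)(=O)NCc2ccccc2)cc1)c1ccc(Cl)cc1Cl`: "not determined" (no result reported)

The read-out here is a functional assay on HEK293 cells for agonist activity at probable G-protein coupled receptor 27 (Homo sapiens), read by a luciferase reporter and beta-arrestin recruitment, with a stated time of 10 min; on this read-out higher numbers stand for larger maximal responses and lower numbers for smaller maximal responses. In this assay compound 1 gives 37%, a partial maximal response relative to the reference. Within the data shown here, compound 1 is the only compound of the three with a number at all, since compound 2 gives "not determined" (no result reported) and compound 3 gives "not determined" (no result reported), so nothing can be said of how compound 1 stands against them beyond that.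

Compound 4 `N#Cc1ccc(C(=O)Nc2ccc(S(=O)(=O)Nc3ccccc3)cc2)c(F)c1` has not yet been measured. It differs from compound 1 in one place: 4-cyano-2-fluorophenyl in place of 4-chloro-2,5-difluorophenyl on a carbonyl carbon. The shared core, the amide link and the sulfonamide part stay as they are in compound 1.

Among the measured compounds shown here, no pair of measured compounds differs in one place, so no measured step gives a hint of how much a change on this ring moves the maximal response. With only compound 1 as an anchor, the step from compound 1 to compound 4 is expected to be small, within or near the scatter, in no firm direction: a number 2 percentage points lower from compound 1 to compound 4 (within the scatter). Compound 4 is therefore estimated at 35%, with a range from 10% to 65%.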

Compound 4, largest response reached (Emax), in percent of the reference or control that the assay uses: 29%
Compound 4: the middle estimate sits 6 percentage points above what was measured; measured number inside the range.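

In this assay, among these compounds, the only measured step on the ring held by the carbonyl carbon reads a number 8 percentage points lower from compound 1 to compound 4 (within the scatter) and gives a first look at this position. It shows that 4-cyano-2-fluorophenyl can take the place of 4-chloro-2,5-difluorophenyl with the maximal response staying within the usual scatter, even though the swap brings in a nitrile and removes the chlorine and one fluorine. No measurement at hand explains this result.

As far as these compounds go, whether any group on this ring can move the maximal response beyond the scatter stays open, for instance a carboxylic acid or an amine in place of the nitrile. Among the compounds shown here, this one step touches only this ring, so the effect of a change in the sulfonamide part, such as a morpholine in place of its phenyl ring, also remains unknown.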